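A few compounds are considered here, and "the series" means these few. Any claim that something is new, unique, unknown or untested is made for them only; others in the source may bear on it.

Series notes. The shared core of compound 1 `C=CC1=C(C(=O)NCCC)C(c2ccc(F)cc2)OC1` carries an amide bearing a propyl chain; in a functional assay on A549 cells (Homo sapiens) for cytotoxicity, read by MTT assay, with a stated time of 24 h (on this read-out higher numbers stand for weaker inhibition and lower numbers for stronger inhibition), compound 1 gives > 100000 nM, which is a limit of the assay and not a number. Compound 3 `C=CC1=C(C(=O)NC(C)(C)C)C(c2ccc(Cl)c(Cl)c2)OC1` likewise returns only a limit in this assay, > 100000 nM. Going by the values given here, the one numbered value among the three comes from compound 2 `C=CC1=C(C(=O)Nc2ccc(OCC)cc2)C(c2ccc(OC)cc2)OC1`, which in this assay gives 17600 nM. Compound 1 thus stands at the limit of > 100000 nM in this assay, at which 2 of the 3 values shown sit, together with compound 3, and carries no number of its own; a limit cannot be ordered against the value of compound 2.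

Compound 4 `C=CC1=C(C(=O)NCCCCC)C(c2ccc(F)cc2)OC1` differs from compound 1 by ethyl in place of hydrogen on a saturated chain carbon, three bonds along the chain from an amide-type nitrogen, so the chain on the amide-type nitrogen reads propyl to pentyl. Among the compounds with values here, no pair of measured compounds differs in one place, so nothing measured sets the size of a step of this kind. The step in this assay from compound 1 to compound 4 is expected to be small, toward stronger inhibition if anything, and not clearly beyond the scatter, so an at least 1.2-fold lower number from compound 1 to compound 4 (0.09 log units; that floor lies within the scatter) is the expected change. Compound 4 is expected in this assay near 80000 nM, in the range 20000 nM to 300000 nM, with a real chance that only a limit is returned again.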

Compound 4, half-maximal inhibitory concentration: > 100000 nM
Compound 4: only a limit was reported (the forecaster's own chance of this, stated with the estimate: 55%); middle value at least 1.2-fold (0.09 log units) from the limit.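

Compound 4 gives > 100000 nM in this assay, again a limit of the assay and not a number. Compound 1 also stands at a limit, so no step from compound 1 to compound 4 can be read: the limit of > 100000 nM in this assay, at which 3 of the 4 values shown sit.

The compounds shown leave open whether the change from propyl to pentyl on the amide-type nitrogen moves the read-out at all.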